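Three Amide Variants and Their Cytotoxicity Toward Liver Cells

The compounds below may be only part of what the source reports. "The series", "measured", "known", "first", "only" and "open" are said of these compounds alone.

Measured in an ADME assay on HepG2 2.2.15 cells (Homo sapiens) for cytotoxicity, read by MTT assay, with stated times of 48 h and 9 days; on this read-out higher numbers stand for lower toxicity in this test and lower numbers for higher toxicity in this test:
Compound 1 `COc1ccc2c(=O)c(/C=C/C(=O)Nc3cccc(Cl)c3)coc2c1`: 1100000 nM
Compound 2 `COc1ccc2c(=O)c(/C=C/C(=O)Nc3ccc(Cl)cc3)coc2c1`: 272000 nM

Of the two measured compounds, compound 2 shows the lower number, so in this assay it is the more toxic of the pair. Among the compounds with values here, the only recorded step, a 4.0-fold lower number from compound 1 to compound 2 (0.61 log units; beyond the scatter), arises from moving the chlorine from one position of the phenyl ring to another on the amide-type nitrogen.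

Compound 3 `COc1ccc(CNC(=O)/C=C/c2coc3cc(OC)ccc3c2=O)cc1` is not yet measured. It differs from compound 2 by 4-methoxybenzyl in place of 4-chlorophenyl on an amide-type nitrogen. Within the data shown here, no measured step exchanges a phenyl for a benzyl group at this nitrogen, so the direction of the change is not fixed by the data. Among the measured compounds shown here, the one step on record, a 4.0-fold lower number from compound 1 to compound 2 (0.61 log units; beyond the scatter), shows that a change of the group on this nitrogen can shift the number by a modest amount, and a step of similar size in either direction is all that can be expected here.

Compound 3 is therefore estimated at 500000 nM, within a range of 150000 nM to 2000000 nM, a step of a 1.8-fold higher number from compound 2 to compound 3 (0.26 log units; within the scatter) that is expected to stay close to the scatter.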

Compound 3, half-maximal cytotoxic concentration: 43000 nM
Compound 3: middle estimate off by 12-fold (1.07 log units), on the high side; measured number below the stated range.
By their numbers in this assay, from the lowest: compound 3; then compound 2; then compound 1.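

In this assay, placing 4-methoxybenzyl on the amide-type nitrogen gives a 6.3-fold lower number from compound 2 to compound 3 (0.80 log units; beyond the scatter) when it replaces 4-chlorophenyl and a 26-fold lower number from compound 1 to compound 3 (1.41 log units; beyond the scatter) when it replaces 3-chlorophenyl. Both steps are beyond the scatter and point the same way, which makes compound 3 the most toxic of the three in this test and settles the direction that compounds 1 and 2 left open for this exchange. The earlier pair showed only what moving a chlorine does, whereas these steps show that replacing the whole group on this nitrogen can also shift the number, by a large amount in the case of compound 1, though nothing available here explains the shift.

These steps change two things at once, the chlorine giving way to a methoxy group and the phenyl giving way to a benzyl, so the compounds shown cannot say which of the two matters. A 4-methoxyphenyl or a 4-chlorobenzyl group on this nitrogen would separate them, and a longer chain between the nitrogen and the ring would test how far the trend extends.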